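From 1-phenylethyl to 2-chlorobenzyl on the shared core

A few compounds are considered here, and "the series" means these few. Any claim that something is new, unique, unknown or untested is made for them only; others in the source may bear on it.

In a physicochemical assay for solubility, using the shake flask method, in simulated intestinal fluid, measured as kinetic solubility, with a stated time of 2 h, at 25 degrees C, at pH 6.5 (on this read-out lower numbers stand for lower solubility and higher numbers for higher solubility), compound 3 `Cc1noc(-c2nc(C)c3c(c2N)C(=O)N(C(C)c2ccccc2)C3=O)n1` gives 10900 nM. Compound 2 `Cc1noc(-c2nc(C)c3c(c2N)C(=O)N(CC2CCOCC2)C3=O)n1` gives 5700 nM. The step between them is a 1.9-fold higher number from compound 2 to compound 3 (0.28 log units; within the scatter), so these two values cannot be told apart. Compound 1 `Cc1noc(-c2nc(C)c3c(c2N)C(=O)N(Cc2ccccc2)C3=O)n1` has only a limit, < 5000 nM.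

Compound 4 `Cc1noc(-c2nc(C)c3c(c2N)C(=O)N(Cc2ccccc2Cl)C3=O)n1` differs from compound 3 at one place: 2-chlorobenzyl in place of 1-phenylethyl on an amide-type nitrogen in a ring. It carries 2-chlorobenzyl in place of 1-phenylethyl on an amide-type nitrogen in a ring. The measured step that bears most directly on this change is an at least 2.1-fold higher number from compound 1 to compound 3 (0.33 log units; beyond the scatter), which is methyl in place of hydrogen on a saturated chain carbon bound to an amide-type nitrogen in a ring and an aromatic carbon. Compound 4 lacks that methyl as well. The other step from the limit, an at least 1.1-fold higher number from compound 1 to compound 2 (0.05 log units; that floor lies within the scatter), involves oxan-4-yl in place of phenyl, a change not made here. Going by the values given here, no measured compound carries the chlorine, so that part of the change has no measured guide. A move towards lower numbers is therefore expected, and compound 4 may be reported only as a limit. The estimated change is a 2.0-fold lower number from compound 3 to compound 4 (0.30 log units; within the scatter). For compound 4 the estimated value is 5500 nM, with an expected range from 2800 nM to 11000 nM.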

Compound 4, solubility: < 5000 nM
Compound 4 gave a limit, no number (the forecaster's own chance of this, stated with the estimate: 40%); at least 1.1-fold (0.04 log units) between middle value and limit.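

At the amide-type nitrogen in a ring, 2-chlorobenzyl in place of 1-phenylethyl gives an at least 2.1-fold lower number from compound 3 to compound 4 (0.33 log units; beyond the scatter) in this assay, although the leaving and entering groups have the same count of heavy atoms and each holds one six-membered aromatic ring of carbon only. The change from oxan-4-yl to 2-chlorophenyl on a saturated chain carbon bound to that nitrogen gives an at least 1.1-fold lower number from compound 2 to compound 4 (0.05 log units; that floor lies within the scatter), and this floor does not separate the two compounds. The step from compound 1 to compound 4, the only pair that differs by chloro in place of hydrogen on an aromatic carbon, cannot be read, and the two compounds share one limit: the limit of < 5000 nM in this assay, at which 2 of the 4 values shown sit.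

The compounds shown leave open how much of the step to compound 4 belongs to the missing methyl and how much to the chloro, and the true value of compound 4 remains unknown behind its limit. They also leave open how the read-out would respond to an amine or a carboxylic acid on the aromatic ring, or to a longer chain on the amide-type nitrogen.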